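The source may hold more compounds than are shown below. What is called first, only, known or untested is meant among the compounds shown, and "the series" means these compounds.

In an ADME assay on the whole organism (Rattus norvegicus), at a dose of 2 mg/kg by the oral route (a higher number here means more compound in the circulation at the dose given, a lower number less compound in the circulation), three compounds with related structures have been measured. Compound 1 (`COc1cc(OCc2csc(-c3ccc(C(F)(F)F)cc3)n2)c2cc(-c3cn4nc(OC)sc4n3)oc2c1`) gives 726 ng.h/mL, compound 2 (`COc1cc(OCc2cccc(-c3ccc(C#N)cn3)c2)c2cc(-c3cn4nc(OC)sc4n3)oc2c1`) gives 464 ng.h/mL, and compound 3 (`CNC(=O)c1ccc(-c2nc(COc3cc(OC)cc4oc(-c5cn6nc(OC)sc6n5)cc34)cs2)cc1`) gives 21.9 ng.h/mL, the lowest of the three numbers and well beyond the scatter from the other two. Compound 4 (`COc1cc(OCc2csc(-c3ccccc3)n2)c2cc(-c3cn4nc(OC)sc4n3)oc2c1`) has not yet been measured in this assay. It differs from compound 3 by hydrogen in place of methylcarbamoyl on an aromatic carbon, para to a large group: hydrogen in place of methylcarbamoyl on an aromatic carbon.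

Among the compounds with values here, one measured step bears on this change: a 33-fold lower number from compound 1 to compound 3 (1.52 log units; beyond the scatter), where methylcarbamoyl took the place of trifluoromethyl on an aromatic carbon. This large step ended at the compound that carries methylcarbamoyl, so removing that group is expected to give a large move towards a higher number. Within the data shown here, no measured compound carries hydrogen at that place, and the expectation rests on this single pair. The expected step is a 16-fold higher number from compound 3 to compound 4 (1.20 log units; beyond the scatter). For compound 4 the estimated value is 350 ng.h/mL, with an expected range of 90 ng.h/mL to 1000 ng.h/mL.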

Compound 4, area under the concentration-time curve: 3920 ng.h/mL
Compound 4: the middle estimate sits 11-fold (1.05 log units) below what was measured, and the stated range ends below it.
By their numbers in this assay, from the lowest: compound 3; then compounds 2 and 1 (each within the scatter of the next); then compound 4.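

In this assay, the change from 4-(methylcarbamoyl)phenyl to phenyl gave a far larger rise than the earlier pair had suggested (a 180-fold higher number from compound 3 to compound 4 (2.25 log units; beyond the scatter)). Hydrogen also stands above trifluoromethyl at this place (a 5.4-fold higher number from compound 1 to compound 4 (0.73 log units; beyond the scatter)), so the earlier compounds' highest number was not the ceiling here, and both groups on this aromatic carbon go with less compound in the circulation than hydrogen, methylcarbamoyl by far the more. Nothing measured here explains these moves.

The compounds shown leave open whether a single fluorine or a methyl at this place would keep the number near that of compound 4, or whether an amine or a carboxylic acid would bring it down as far as methylcarbamoyl does. They also leave open whether removing the nitrile from compound 2 would bring a rise of similar size.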